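This account rests on a few compounds, and the source may have more. Where it says the series, first, only, none or still open, it means among the compounds named here.

In a physicochemical assay for solubility, at pH 7 (a lower number here means a less soluble compound, a higher number a more soluble compound), compound 2 (`CN1CCC(C(=O)N2Cc3c(NC(=O)NCc4ccccc4)n[nH]c3C2(C)C)CC1`) gives > 225000 nM, which is a limit of the assay and not a number. Compound 1 (`CN1CCC(C(=O)N2Cc3c(NC(=O)C4CC4)n[nH]c3C2(C)C)CC1`) gives > 225000 nM, likewise a limit. The series thus has two compounds at the limit of > 225000 nM in this assay, at which 2 of the 3 values shown sit. Going by the values given here, the only measured step, a step that the two limits leave unreadable from compound 1 to compound 2, offers no size to carry forward. Among the compounds with values here, compound 3 (`CC(C)(C)C(=O)N1Cc2c(NC(=O)c3ccc(F)cc3)n[nH]c2C1(C)C`) gives 235000 nM, the one true number in this assay so far.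

The next step leads to compound 4 (`CN1CCC(C(=O)N2Cc3c(NC(=O)c4ccsc4)n[nH]c3C2(C)C)CC1`), and the change is thiophen-3-yl in place of benzylamino on a carbonyl carbon. In words, thiophen-3-yl takes the place of benzylamino on a carbonyl carbon, and the rest of compound 2 stays as it is.

Within the data shown here, no measured step covers this exact change, so the expectation rests on thin evidence. The closest guide is compound 3, with 235000 nM, which also has an aromatic ring on that carbonyl but differs from compound 4 elsewhere too. On that basis, no shift beyond the scatter is expected in either direction, and another limit reading would be no surprise. The estimated step is a number no higher from compound 2 to compound 4 (the limit leaves the size open). For compound 4 the estimated value is 225000 nM, with an expected range from 120000 nM to 280000 nM.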

Compound 4, solubility: > 225000 nM
Compound 4: a limit, no number (the forecaster's own chance of this, stated with the estimate: 60%); the middle value lies on the limit itself.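

In this assay compound 4 gives > 225000 nM, a limit of the assay and not a number. The steps linking compound 1, compound 2 and compound 4 therefore cannot be read, as all three sit at one limit: the limit of > 225000 nM in this assay, at which 3 of the 4 values shown sit.

The compounds shown leave open how cyclopropyl, benzylamino and thiophen-3-yl on the carbonyl carbon compare in this assay.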